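This account rests on a few compounds, and the source may have more. Where it says the series, first, only, none or still open, it means among the compounds named here.

Measured so far in a toxicity assay on HeLa cells (Homo sapiens) for cytotoxicity; on this read-out higher numbers stand for lower toxicity in this test and lower numbers for higher toxicity in this test:
- compound 2 `COc1nc(C2CCCCC2)ccc1[C@@H](c1ccccc1)[C@@](O)(CCN(C)C)c1cccc2ccccc12` gives 57.7 ug/mL
- compound 3 `COc1nc(-c2ccncc2)ccc1[C@@H](c1ccccc1)[C@@](O)(CCN(C)C)c1cccc2ccccc12` gives 9.6 ug/mL
- compound 1 `COc1nc(-c2ccccc2F)ccc1[C@@H](c1ccccc1)[C@@](O)(CCN(C)C)c1cccc2ccccc12` gives "nd" (no result reported), that is, no result in this assay

Compound 3 stands at the lower of the two numbers; its nearest neighbour is compound 2, and the step of a 6.0-fold lower number from compound 2 to compound 3 (0.78 log units; beyond the scatter) lies beyond the scatter. Compound 4 `COc1ccc(-c2ccc([C@@H](c3ccccc3)[C@@](O)(CCN(C)C)c3cccc4ccccc34)c(OC)n2)cc1` differs from compound 3 by 4-methoxyphenyl in place of pyridin-4-yl on an aromatic carbon. Going by the values given here, only one measured step touches this position, the exchange of a cyclohexyl for a pyridin-4-yl between compound 2 and compound 3, which moved the number downward. Replacing the pyridin-4-yl with 4-methoxyphenyl is a new change, so compound 4 is expected to land between those two neighbours, with a step of a 2.6-fold higher number from compound 3 to compound 4 (0.42 log units; beyond the scatter) upward. Compound 4 is estimated at 25 ug/mL, within 8 ug/mL to 70 ug/mL.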

Compound 4, half-maximal cytotoxic concentration: > 64 ug/mL
Compound 4: no number, only a limit; the forecaster's own chance of this, stated with the estimate: 5%; middle value at least 2.5-fold (0.40 log units) away from the limit.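

In this assay compound 4 gives > 64 ug/mL, a limit of the assay and not a number. The exchange of pyridin-4-yl for 4-methoxyphenyl gives an at least 6.6-fold higher number from compound 3 to compound 4 (0.82 log units; beyond the scatter), so a six-membered aromatic ring at this position does not by itself bring the lower number. The exchange of cyclohexyl for 4-methoxyphenyl gives an at least 1.1-fold higher number from compound 2 to compound 4 (0.04 log units; that floor lies within the scatter), so these two compounds cannot be put in order.

From the compounds shown here alone, how far the true number of compound 4 lies past this limit stays open: the limit of > 64 ug/mL in this assay, at which 1 of the 4 values shown sits. Also open is where an amine or a carboxylic acid at this position would fall on this read-out.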